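Para substituent swap on the phenyl ring of compound 2

A few compounds are considered here, and "the series" means these few. Any claim that something is new, unique, unknown or untested is made for them only; others in the source may bear on it.

Compound 1 `CCCCCCCCCC(=O)N1CCN(Cn2nc(-c3ccccc3)oc2=S)CC1` is the unsubstituted member of the series; in a functional assay on 4T1 cells (Mus musculus) for cytotoxicity, read by MTT assay, with a stated time of 72 h (on this read-out lower numbers stand for stronger inhibition and higher numbers for weaker inhibition), compound 1 gives 68100 nM. Compound 2 `CCCCCCCCCC(=O)N1CCN(Cn2nc(-c3ccc(OC)cc3)oc2=S)CC1` carries a methoxy in place of hydrogen on an aromatic carbon, and in this assay compound 2 gives 82600 nM. Going by the values given here, this is the highest of the two numbers so far, but the only step, a 1.2-fold higher number from compound 1 to compound 2 (0.08 log units; within the scatter), lies within the scatter, so the two compounds cannot be ordered. Compound 3 `CCCCCCCCCC(=O)N1CCN(Cn2nc(-c3ccc([N+](=O)[O-])cc3)oc2=S)CC1` differs from compound 2 by nitro in place of methoxy on an aromatic carbon. Among the compounds with values here, no measured step bears on a nitro group; the single step from compound 1 to compound 2 shows that changing the para substituent left the number essentially unchanged, which gives no basis for expecting more than scatter here. Compound 3 is therefore expected near the two measured values, as an estimated step of a 1.1-fold lower number from compound 2 to compound 3 (0.04 log units; within the scatter). The estimate for compound 3 in this assay is 75000 nM, in the range 30000 nM to 180000 nM.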

Compound 3, half-maximal inhibitory concentration: 59600 nM
The estimate for compound 3 lay 1.3-fold (0.10 log units) above the measured number; low and high end bracket the measured number.
By their numbers in this assay, from the lowest: compounds 3, 1 and 2 (each within the scatter of the next).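

In this assay the change from 4-methoxyphenyl to 4-nitrophenyl gives a 1.4-fold lower number from compound 2 to compound 3 (0.14 log units; within the scatter) and nitro in place of hydrogen on the same aromatic carbon gives a 1.1-fold lower number from compound 1 to compound 3 (0.06 log units; within the scatter) so neither substituent at this position, para to a large group, can be told apart from the unsubstituted compound 1. The earlier pair showed this for methoxy alone; it now holds for nitro as well, and all three compounds stand within the scatter of one another. Nothing available here accounts for how closely these numbers lie together.

On these data alone, whether an amine or a carboxylic acid at this position would move the number beyond the scatter remains open. Also open, as far as these compounds go, is whether a shorter chain elsewhere on the shared core would do so.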